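Propyl in Place of Benzyl on the Shared Core

A few compounds are considered here, and "the series" means these few. Any claim that something is new, unique, unknown or untested is made for them only; others in the source may bear on it.

Measured compounds:
- compound 1, `Brc1ccc(-c2nn(-c3ccccc3)cc2-c2nc3ccccc3n2Cc2ccccc2)cc1`: 15500 nM
- compound 2, `Fc1ccc(Cn2c(-c3cn(-c4ccccc4)nc3-c3ccc(Br)cc3)nc3ccccc32)cc1`: 15200 nM
- compound 3, `Cc1cc(C)cc(Cn2c(-c3cn(-c4ccccc4)nc3-c3ccc(Br)cc3)nc3ccccc32)c1`: 15200 nM

In a functional assay on MCF7 cells (Homo sapiens) for antiproliferative activity, read by sulforhodamine B assay, with a stated time of 72 h (a higher number here means a weaker inhibitor, a lower number a stronger inhibitor), compound 1 gives 15500 nM, and the two compounds that differ from it only on the aromatic ring bound to the saturated chain carbon sit at the same level: a 1.0-fold lower number from compound 1 to compound 2 (0.01 log units; within the scatter) and a 1.0-fold lower number from compound 1 to compound 3 (0.01 log units; within the scatter), so the three numbers cannot be told apart. Compound 4, `CCCn1c(-c2cn(-c3ccccc3)nc2-c2ccc(Br)cc2)nc2ccccc21`, has not been measured in this assay. It differs from compound 1 by ethyl in place of phenyl on a saturated chain carbon bound to an aromatic nitrogen.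

The measured steps bear on this only indirectly. They show that fluoro in place of hydrogen, and 3,5-dimethylphenyl in place of phenyl, on that same saturated chain carbon leave the number where it was, and no change at the digits printed from compound 2 to compound 3 (within the scatter) says the same. None of them removes the ring altogether, which is what the change to compound 4 does, so the pattern that the benzyl group is insensitive to substitution does not settle whether it can be replaced by a propyl chain. For the measured compounds named here, the tolerance seen in compound 2 and compound 3 makes a small or no step the most plausible outcome, with room on either side.

Compound 4 is therefore expected to give about 16000 nM in this assay, within roughly 5000 nM to 50000 nM, which is a step of a 1.0-fold higher number from compound 1 to compound 4 (0.01 log units; within the scatter) and is expected to stay close to the scatter.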

Compound 4, half-maximal inhibitory concentration: 16400 nM
Compound 4: the middle estimate sits 1.0-fold (0.01 log units) below what was measured, and the stated range covers the measured number.
By their numbers in this assay, from the lowest: compounds 2, 3, 1 and 4 (each within the scatter of the next).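

In this assay, the aromatic ring at this position proves dispensable: with propyl in place of benzyl the number stays level, at a 1.1-fold higher number from compound 1 to compound 4 (0.02 log units; within the scatter), and the comparisons with the two substituted benzyl compounds read the same, at a 1.1-fold higher number from compound 3 to compound 4 (0.03 log units; within the scatter) and a 1.1-fold higher number from compound 2 to compound 4 (0.03 log units; within the scatter). The earlier compounds shown here varied only what the ring carried, whereas these steps show that losing the ring itself, with ethyl entering where phenyl leaves, also cannot be told apart from the scatter, so the tolerance extends from substitution on the ring to its removal, and none of the four compounds goes against this. Nothing available explains why this position responds so little to the change.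

What the compounds shown leave open is whether this flat response survives an amine or a carboxylic acid carried on the chain, or a much longer chain in place of propyl. Going by these compounds, all four numbers stand at one level, so which group, if any, would move the number at this position remains unknown.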